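This account rests on a few compounds, and the source may have more. Where it says the series, first, only, none or still open, it means among the compounds named here.

Compound 1 `CCC(=O)N1CCC(CN(C2Cc3cc(C#N)ccc3N(Cc3cncn3C)C2)S(=O)(=O)c2ccccn2)CC1` has been measured in an ADME assay on Caco-2 cells (Homo sapiens) for permeability, in the apical to basolateral direction (on this read-out higher numbers stand for higher permeability and lower numbers for lower permeability), and gives 0.5 10^-6 cm/s. That is the higher of the two numbers obtained so far. Going by the values given here, its only measured neighbour, compound 2 `CCS(=O)(=O)N1CCC(CN(C2Cc3cc(C#N)ccc3N(Cc3cncn3C)C2)S(=O)(=O)c2ccccn2)CC1`, gives 0.1 10^-6 cm/s in this assay, and the one step between them, a 5.0-fold lower number from compound 1 to compound 2 (0.70 log units; beyond the scatter), is the single point of comparison available. Compound 3 `Cn1cncc1CN1CC(N(CC2CCN(S(=O)(=O)c3ccccc3)CC2)S(=O)(=O)c2ccccn2)Cc2cc(C#N)ccc21` has not yet been measured. It differs from compound 1 in one place: phenylsulfonyl in place of propanoyl on an amine nitrogen in a ring. This resembles the change from compound 1 to compound 2, where an ethylsulfonyl rather than a phenylsulfonyl took the place of the propanoyl, so that step is the one that bears on it. A lower number of roughly that size is therefore expected for compound 3, a 3.3-fold lower number from compound 1 to compound 3 (0.52 log units; beyond the scatter). Compound 3 is estimated to give 0.15 10^-6 cm/s in this assay, with a range from 0.04 10^-6 cm/s to 0.6 10^-6 cm/s.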

Compound 3, apparent permeability: 0.1 10^-6 cm/s
Compound 3: the middle estimate sits 1.5-fold (0.18 log units) above what was measured, and the stated range covers the measured number.
By their numbers in this assay, from the lowest: compounds 2 and 3 (each within the scatter of the next); then compound 1.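

In this assay, a second sulfonyl group on the ring nitrogen behaves like the first: phenylsulfonyl in place of propanoyl gives the same result as ethylsulfonyl (a 5.0-fold lower number from compound 1 to compound 3 (0.70 log units; beyond the scatter)). The group on the sulfonyl sulfur makes no visible difference, since phenyl in place of ethyl, despite adding an aromatic ring, leaves the number where it was (no change at the digits printed from compound 2 to compound 3 (within the scatter)). So, across these three compounds, both sulfonyl compounds sit lower than the propanoyl compound, with neither going against this, but no measurement here accounts for the pattern.

A benzoyl group on this nitrogen, the carbonyl counterpart of phenylsulfonyl, could show whether the number stays near that of compound 1 or matches that of compound 3. A simple methyl group there would show how the ring nitrogen behaves with neither a carbonyl nor a sulfonyl attached.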